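A few compounds are considered here, and "the series" means these few. Any claim that something is new, unique, unknown or untested is made for them only; others in the source may bear on it.

Working notes on the series in an assay on isolated protein for inhibition of Polyunsaturated fatty acid 5-lipoxygenase (Rattus norvegicus); a higher number here means a weaker inhibitor, a lower number a stronger inhibitor.

Compound 1 `COCCC1CN(c2ccccc2)NC1=O` carries the 2-methoxyethyl group on the shared core and has been run repeatedly in this assay: compound 1 gives 480 nM; 10300 nM; 350 nM (3 entries), and the spread of those entries is wide, see (the several entries of compound 1 in this assay, 480 nM; 10300 nM; 350 nM (3 entries)). Compound 2 `CCSC1CN(c2ccccc2)NC1=O` replaces that side chain with an ethylthio group; in this assay compound 2 gives 60 nM. Compound 3 `COCCC1C(=O)NN(c2ccccc2)C1C` keeps the 2-methoxyethyl group and adds a methyl on the saturated ring carbon; in this assay compound 3 gives 500 nM. Among the two single numbers, compound 3 stands highest, and the gap to compound 2 lies beyond the scatter, while the entries of compound 1 bracket the value of compound 3 without giving a single number for comparison.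

Compound 4 `COCCC1C(=O)NN(c2ccccc2)C1(C)C` is not yet measured. It differs from compound 3 by methyl in place of hydrogen on a saturated ring carbon, a methyl in place of hydrogen on a saturated ring carbon. For the measured compounds named here, no measured pair in the set isolates this change, so the expectation rests on the weight of the series. A second methyl on the same ring carbon is expected to shift the number only modestly, if at all, toward a weaker inhibitor: the step of a 1.4-fold higher number from compound 3 to compound 4 (0.15 log units; within the scatter) is the estimate here. For compound 4 in this assay the expected value is 700 nM, with a range from 250 nM to 2000 nM.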

Compound 4, half-maximal inhibitory concentration: > 1000 nM
Compound 4: no number, only a limit; the forecaster's own chance of this, stated with the estimate: 5%; middle value at least 1.4-fold (0.15 log units) from the limit.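

In this assay compound 4 gives > 1000 nM, which is a limit of the assay and not a number: the limit of > 1000 nM in this assay, at which 1 of the 4 values shown sits.

For the compounds shown here, this is the first readable step at this position, where methyl replaces hydrogen on a saturated ring carbon that already bears a methyl, and this assay shows an at least 2.0-fold higher number from compound 3 to compound 4 (0.30 log units; that floor lies within the scatter). The floor alone does not place this change beyond the scatter, while the data set no upper end on its size, so the second methyl gives a one-sided result rather than a measured step.

From the compounds shown here alone, the effect of the first methyl on this ring carbon cannot be read, since compound 1 offers no single number to set against compound 3: the several entries of compound 1 in this assay, 480 nM; 10300 nM; 350 nM (3 entries) Also open is how an ethyl group, an amine or a carboxylic acid on this saturated ring carbon would read in this assay, and whether a ring methyl would change the number of compound 2, which stands at 60 nM with its ethylthio group.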